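A Methoxy Group Added to a Weak Chloro Analogue

The source may hold more compounds than are shown below. What is called first, only, known or untested is meant among the compounds shown, and "the series" means these compounds.

Within the data shown here, compound 1 `CCN(CC)CN1C(=O)/C(=N/NC(=S)Nc2ccccc2)c2cc(Cl)ccc21` is the weakest of the two compounds measured so far. In a functional assay on CCRF-CEM cells (Homo sapiens) for inhibition, read by cell counting, with a stated time of 72 h (on this read-out higher numbers stand for weaker inhibition and lower numbers for stronger inhibition), compound 1 gives 40000 nM, the highest of the two numbers. Its nearest neighbour is compound 2 `CCN(CC)CN1C(=O)/C(=N/NC(=S)Nc2ccccc2)c2ccccc21`, which in this assay gives 11000 nM. Among the measured compounds shown here, the single measured step, a 3.6-fold lower number from compound 1 to compound 2 (0.56 log units; beyond the scatter), comes from hydrogen in place of chloro on an aromatic carbon of the shared core.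

Compound 3 `CCN(CC)CN1C(=O)/C(=N/NC(=S)Nc2ccc(OC)cc2)c2cc(Cl)ccc21` keeps the chloro of compound 1 and differs from it elsewhere: methoxy in place of hydrogen on an aromatic carbon. For the measured compounds named here, no measured step touches this ring or this kind of change, so the one measured step gives no direct guide; it concerns a different position and a different group. With nothing to point either way, compound 3 is expected to remain close to compound 1, with a step of a 1.3-fold lower number from compound 1 to compound 3 (0.12 log units; within the scatter) that lies within the usual scatter. Compound 3 is therefore estimated at 30000 nM in this assay, with a range from 10000 nM to 90000 nM.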

Compound 3, half-maximal inhibitory concentration: 6900 nM
Estimate against measurement, compound 3: 4.3-fold (0.64 log units) above; measured number below the stated range.
By their numbers in this assay, from the lowest: compounds 3 and 2 (each within the scatter of the next); then compound 1.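

In this assay, the change from phenyl to 4-methoxyphenyl gives a 5.8-fold lower number from compound 1 to compound 3 (0.76 log units; beyond the scatter), a step beyond the scatter. Among these compounds, until now the only measured step, a 3.6-fold lower number from compound 1 to compound 2 (0.56 log units; beyond the scatter), lay at the chloro site of the shared core; this result shows that the anilino end of the molecule also moves the number, with the chloro left in place. A single methoxy group at this place, para to a large group, is therefore enough to take the weak chloro analogue compound 1 to a clearly lower number, although the data give no measured basis for explaining that shift.

The compounds shown leave open whether the methoxy step depends on the chloro, as methoxy appears here only together with that group, and a methoxy on the chloro-free core of compound 2 would be needed to settle this. They also leave open whether the step belongs to methoxy in particular or would be shared by a hydroxyl, an amine or a longer chain such as ethoxy at the same place.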